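This account rests on a few compounds, and the source may have more. Where it says the series, first, only, none or still open, it means among the compounds named here.

Measured in a functional assay on HepG2 cells (Homo sapiens), read by MTT assay, with a stated time of 48 h; on this read-out higher numbers stand for weaker inhibition and lower numbers for stronger inhibition:
- compound 1 `CCn1c(C(=O)NCCN(C)C)ccc1C(CC)(CC)c1ccc(OCC(=O)C(C)(C)C)c(C)c1`: 2300 nM
- compound 2 `CCOC(=O)CN(C)C(=O)c1ccc(C(CC)(CC)c2ccc(OCC(O)C(C)(C)C)c(C)c2)n1CC`: > 50000 nM

The entry for compound 2, > 50000 nM, is a limit of the assay and not a number. Compound 3 `CCN(CC)CCCNC(=O)c1ccc(C(CC)(CC)c2ccc(OCC(O)C(C)(C)C)c(C)c2)n1CC` has (3-(diethylamino)propyl)amino in place of ((ethoxycarbonyl)methyl)(methyl)amino on a carbonyl carbon. Within the data shown here, compound 1, at 2300 nM, is the only guide, and it differs from compound 3 in more than one place. A large step towards stronger inhibition is expected in this assay, estimated as an at least 8.3-fold lower number from compound 2 to compound 3 (0.92 log units; beyond the scatter). The expected value for compound 3 is 6000 nM, within 1500 nM to 30000 nM.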

Compound 3, half-maximal inhibitory concentration: 1100 nM
The estimate for compound 3 lay 5.5-fold (0.74 log units) above the measured number; measured number outside the range, below it.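

In this assay, (3-(diethylamino)propyl)amino in place of ((ethoxycarbonyl)methyl)(methyl)amino on a carbonyl carbon gives an at least 45-fold lower number from compound 2 to compound 3 (1.65 log units; beyond the scatter), so this one place alone can move the series from the limit into a measurable range. Compound 2 stands at a limit of the assay and not a number, so the true size of the step stays open: the limit of > 50000 nM in this assay, at which 1 of the 3 values shown sits.

The change alters the amide hydrogen and the chain end together, and the compounds shown do not separate the two. A morpholine at the chain end, or a shorter chain carrying the same diethylamino end, would test which part carries the step.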